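The source may hold more compounds than are shown below. What is called first, only, known or untested is meant among the compounds shown, and "the series" means these compounds.

The measured compounds:
Compound 1 `COc1ccc(-c2c(C)nc3c(N4CC[C@@H](NC(C)=O)C4)cc(C)nn23)cc1OC`, a limit in an ADME assay on microsomes from liver (Mus musculus) for metabolic stability, read by LC-MS, with NADPH named in the record, with a stated time of 60 min, tested at 1 uM, in the absence of a further agent; a lower number here means that less of the compound is left, a higher number that more of the compound is left: > 95%.
Compound 2 `CC(=O)N[C@@H]1CCN(c2cc(C)nn3c(-c4nccs4)c(C)nc23)C1`, a limit in this assay: > 95%.
Compound 3 `COc1ccc(-c2c(C)nc3c(N4CC[C@@H](NC(C)=O)C4)cc(Cl)nn23)cc1OC`, a limit in this assay: > 95%.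

Compound 1 stands at the upper edge of what this assay reports; its value is a limit, not a number. The same holds for the two other compounds, as the limit of > 95% in this assay, at which 3 of the 3 values shown sit, shows. The change that leads to compound 4 `COc1ccc(-c2c(C)nc3c(N4CC[C@@H](NS(=O)(=O)c5ccc(C(C)=O)cc5)C4)cc(C)nn23)cc1OC` is (4-acetylphenyl)sulfonyl in place of acetyl on an amine nitrogen.

Two measured steps start from compound 1, but neither has a readable size: a step that the two limits leave unreadable from compound 1 to compound 2 and a step that the two limits leave unreadable from compound 1 to compound 3. For the measured compounds named here, they show only that exchanging the aromatic group, or methyl for chloro, did not bring the value out of the limit. Nothing measured concerns a change on the amine nitrogen, and the entering group is larger than the one it replaces. A fall beyond the scatter is expected, though a value at the limit remains possible. The step from compound 1 to compound 4 is expected as a number at least 15 percentage points lower from compound 1 to compound 4 (beyond the scatter). Compound 4 is estimated at 80%, in the range 55% to 98%.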

Compound 4, percent of the compound remaining: > 95%
Compound 4: no number, only a limit; the forecaster's own chance of this, stated with the estimate: 40%; middle value at least 15 percentage points away from the limit.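

Compound 4 gives > 95% in this assay as a limit and not a number. Compound 1 also stands at a limit, so no size can be read for the change between compound 1 and compound 4. The compounds shown leave open which change, if any, lowers the percent remaining.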